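The compounds below may be only part of what the source reports. "The series", "measured", "known", "first", "only" and "open" are said of these compounds alone.

Measured so far in an assay on Sf9 cells for inhibition of histone deacetylase 11 (Homo sapiens), read by fluorescence, tested at 0.5 uM; on this read-out lower numbers stand for less inhibition and higher numbers for more inhibition at the one concentration tested (going by the name of the read-out):
- compound 1, `O=C(/C=C/c1cn([C@H]2C[C@H](CO)N(Cc3ccccc3)C2)nn1)NO`: 20%
- compound 2, `O=C(/C=C/c1cn([C@H]2C[C@H](C(=O)O)N(CCCc3ccccc3)C2)nn1)NO`: 20%

Compound 2 stands level with compound 1 at the digits read; the two values lie within the usual scatter of this assay, so no order between them can be stated. Within the data shown here, both share the core and differ in two places at once, so no single step between them is counted here; their values only show that neither change, taken together, moved the read-out beyond the scatter.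

Compound 3, `O=C(/C=C/c1cn([C@H]2C[C@H](C(=O)O)N(Cc3ccccc3)C2)nn1)NO`, has not yet been measured. It departs from compound 2 by one change, (phenyl in place of phenethyl on a saturated chain carbon bound to an amine nitrogen in a ring), so that the chain on the ring amine nitrogen is shortened while the carboxylic acid of compound 2 is kept.

Among the measured compounds shown here, no measured pair in this set isolates the effect of the chain length, so there is nothing to set a direction on. Given that compound 1 with a benzyl chain and compound 2 with a 3-phenylpropyl chain sit level, the expectation for this assay is a step no larger than the scatter, no change at the digits printed from compound 2 to compound 3 (within the scatter). For compound 3 the estimated result in this assay is 20%, with a range from 5% to 40%.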

Compound 3, a percentage reported as inhibition, at one concentration (the size of the read-out at that concentration, not a potency): 14%
Compound 3: middle estimate off by 6 percentage points, on the high side; measured number inside the range.
By their numbers in this assay, from the lowest: compounds 3, 1 and 2 (each within the scatter of the next).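

Among these compounds, compound 3 gives the first single-place readings in this assay: on the saturated chain carbon bound to the ring amine nitrogen, the exchange of 3-phenylpropyl for benzyl with the carboxylic acid kept gives a number 6 percentage points lower from compound 2 to compound 3 (within the scatter). At the saturated ring carbon, with the benzyl chain kept, carboxy in place of hydroxymethyl gives a number 6 percentage points lower from compound 1 to compound 3 (within the scatter). Neither exchange therefore separates from the scatter at the one concentration tested, which the level values of compound 1 and compound 2 could not show, since those two differ in two places at once, and nothing available explains these readings.

Still open, as far as these compounds go, is how a longer chain than 3-phenylpropyl, or a small group such as methyl on the ring amine nitrogen, would read, and how a primary amide or a methyl ester would compare with the carboxylic acid on the saturated ring carbon. From the compounds shown here alone, with a single concentration and all steps within the scatter, no ranking of these three compounds can be drawn, and their potency stays unknown.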